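A few compounds are considered here, and "the series" means these few. Any claim that something is new, unique, unknown or untested is made for them only; others in the source may bear on it.

Three compounds share one core and differ only in the length of a saturated chain on an oxygen. In a functional assay, with stated times of 30 s and 6 min, in the presence of a further agent that is not named here (a lower number here means a stronger inhibitor, a higher number a weaker inhibitor), compound 1 `CCCCOc1cc(OC)c(Br)cc1C(C)=O` gives 38200000 nM, compound 2 `CCCCCCCCCCOc1cc(OC)c(Br)cc1C(C)=O` gives 15000000 nM and compound 3 `CCCCCCCCCCCCOc1cc(OC)c(Br)cc1C(C)=O` gives 10600000 nM. Compound 3 sits at the low end of these numbers, but it is not separated from its nearest neighbour: the data show a 1.4-fold lower number from compound 2 to compound 3 (0.15 log units; within the scatter). The clear separation is from the shortest chain, with a 3.6-fold lower number from compound 1 to compound 3 (0.56 log units; beyond the scatter), and a 2.5-fold lower number from compound 1 to compound 2 (0.41 log units; beyond the scatter) is similarly modest.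

Compound 4 `CCCCCCCCCCCCCCCCOc1cc(OC)c(Br)cc1C(C)=O` carries the next change, (butyl in place of hydrogen on a saturated chain carbon, ten or more bonds along the chain from an oxygen on an aromatic ring), which again extends the chain. Among the compounds with values here, the closest precedent is a 1.4-fold lower number from compound 2 to compound 3 (0.15 log units; within the scatter), made at the same kind of place with a smaller group. The two larger steps show that lengthening the chain has lowered the number only modestly, even across a long stretch. The data do not show whether this drift continues at greater length. A small further fall is therefore expected, with no step beyond the scatter. The estimated change is a 1.5-fold lower number from compound 3 to compound 4 (0.18 log units; within the scatter). In this assay, the estimate for compound 4 is 7000000 nM, with an expected range from 3500000 nM to 14000000 nM.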

Compound 4, half-maximal inhibitory concentration: 1800000 nM
Compound 4: middle estimate off by 3.9-fold (0.59 log units), on the high side, outside the stated range (below it).
By their numbers in this assay, from the lowest: compound 4; then compounds 3 and 2 (each within the scatter of the next); then compound 1.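

At this far stretch of the chain, lengthening still matters in this assay: butyl in place of hydrogen gives a 5.9-fold lower number from compound 3 to compound 4 (0.77 log units; beyond the scatter), whereas the smaller ethyl change at the same kind of place gave only a 1.4-fold lower number from compound 2 to compound 3 (0.15 log units; within the scatter). Hexyl in place of hydrogen at this kind of place gives an 8.3-fold lower number from compound 2 to compound 4 (0.92 log units; beyond the scatter), so the earlier small step does not mean that the effect of chain length had run out by compound 3. No separate measurement here helps explain the drop seen with compound 4.

The compounds shown leave open whether a longer chain than that of compound 4 would lower the number further, hold it steady or raise it again, and so where this trend ends. They also leave open whether the fall depends on the chain being a plain saturated one, which a chain ending in an amine or a carboxylic acid could test.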